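The Same Methyl-to-Hydrogen Change Made on Two Cores

This account rests on a few compounds, and the source may have more. Where it says the series, first, only, none or still open, it means among the compounds named here.

Measured so far in an assay for inhibition of solute carrier family 22 member 12 (Homo sapiens), read by scintillation counting, with a stated time of 60 min, tested at 50 uM; on this read-out higher numbers stand for more inhibition at the one concentration tested (going by the name of the read-out) and lower numbers for less inhibition:
compound 1, `CCc1oc2ccc(OC)cc2c1C(=O)c1ccc(OC)cc1`, gives 24.3%
compound 2, `CCc1oc2ccc(OC)cc2c1C(=O)c1ccc(O)cc1`, gives 92.7%
compound 3, `CCc1cc2c(C(=O)c3ccc(OC)cc3)cc(O)cc2o1`, gives 12.4%

Compound 1 and compound 2 differ in one place, (hydrogen in place of methyl on an oxygen on an aromatic ring), and this change brought a number 68.4 percentage points higher from compound 1 to compound 2 (beyond the scatter). Compound 3 stands on a different core; the difference between the core of compound 3 and the core of compound 1 is not broken down here. Among the three measured compounds, compound 3 has the lowest number. The unmeasured compound 4, `CCc1cc2c(C(=O)c3ccc(O)cc3)cc(O)cc2o1`, differs from compound 3 by hydrogen in place of methyl on an oxygen on an aromatic ring. The place of this change reads the same, word for word, as for the change from compound 1 to compound 2, so it is the same change made a second time, on the other core. Because a number 68.4 percentage points higher from compound 1 to compound 2 (beyond the scatter) was large on the core of compound 1, a rise in the same direction is expected for compound 4, though the core differs, so the size is less certain. The step that this expectation means, a number 47.6 percentage points higher from compound 3 to compound 4 (beyond the scatter), is expected to fall somewhat below the earlier one. Compound 4 is expected to give 60%. The lower end for compound 4 is estimated at 30%. The upper end for compound 4 is estimated at 85%.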

Compound 4, a percentage reported as inhibition, at one concentration (the size of the read-out at that concentration, not a potency): 41%
Compound 4: middle estimate off by 19 percentage points, on the high side, within the range that was stated.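

In this assay, the change from methoxy to hydroxy on the second core gave a number 28.6 percentage points higher from compound 3 to compound 4 (beyond the scatter), and the direction seen on the first core held. The size did not carry over, and the two steps differ by more than the scatter: the same change on two cores in this assay, a number 68.4 percentage points higher (beyond the scatter) from compound 1 to compound 2 and a number 28.6 percentage points higher (beyond the scatter) from compound 3 to compound 4, 39.8 percentage points apart, beyond the scatter of two such steps. For the compounds shown here, with only two cores, this shows that the direction was kept in this pair of cores, but it does not show why the size differs or that the direction would hold on any further core.

The compounds shown leave open whether a similar step would appear if the oxygen carried a longer chain, as in ethoxy, or if an amine or a carboxylic acid stood in place of the hydroxy group. They also leave open whether a third core would give a step closer to the larger one or the smaller one, and how these steps would look at a concentration other than the one tested.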